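Chain homolog of the isothiocyanate amide series

This account rests on a few compounds, and the source may have more. Where it says the series, first, only, none or still open, it means among the compounds named here.

Measured so far:
compound 1 `CN(C)C(=O)c1cc2cnc(Nc3ccc(C(=O)NCCCCCN=C=S)cc3)nc2n1C1CCCC1` — 100%
compound 2 `CN(C)C(=O)c1cc2cnc(Nc3ccc(NC(=O)CCCCN=C=S)cc3)nc2n1C1CCCC1` — 102%

In a functional assay on A549 cells (Homo sapiens) for inhibition, read by CCK-8 assay, with a stated time of 72 h, tested at 10 uM (a higher number here means a stronger effect of the compound at the concentration tested, a lower number a weaker effect), compound 1 gives 100% and compound 2 gives 102%. Compound 2 stands alongside compound 1, the two within the scatter of each other: a number 2 percentage points higher from compound 1 to compound 2 (within the scatter). Compound 3 `CN(C)C(=O)c1cc2cnc(Nc3ccc(NC(=O)CCCCCN=C=S)cc3)nc2n1C1CCCC1` differs from compound 2 by a group of 4 heavy atoms (2 carbon, 1 nitrogen, 1 sulfur; no ring) in place of a group of 3 heavy atoms (1 carbon, 1 nitrogen, 1 sulfur; no ring), on a saturated chain carbon, four bonds along the chain from a carbonyl carbon. Among the measured compounds shown here, the only measured step bears on it as a shift in the same chain region and was within the scatter, so no step beyond the scatter is expected in this assay. Compound 3 is expected near saturation: a number 2 percentage points lower from compound 2 to compound 3 (within the scatter). The estimate for compound 3 is 100%, between 90% and 108%.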

Compound 3, a percentage reported as inhibition, at one concentration (the size of the read-out at that concentration, not a potency): 100%
For compound 3 middle estimate and measured number coincide at the digits printed; measured number inside the range.
By their numbers in this assay, from the lowest: compounds 1, 3 and 2 (each within the scatter of the next).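

In this assay, the group of 4 heavy atoms in place of the group of 3 heavy atoms, on a saturated chain carbon, gives a number 2 percentage points lower from compound 2 to compound 3 (within the scatter), so this chain position tolerates that extension at the concentration tested. The two different groups of 11 heavy atoms, on an aromatic carbon, give no change at the digits printed from compound 1 to compound 3 (within the scatter). Nothing measured here bears on why these compounds read alike.

Going by these compounds, whether an amine or an acrylamide in place of the isothiocyanate, or a much longer chain, would hold this level stays open. On these data alone, whether these compounds would show a stronger or weaker effect than one another at other concentrations also stays open; only one concentration was tested.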